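Quinazoline aryl amine swap: a methyl ester replaces trifluoromethoxy

A few compounds are considered here, and "the series" means these few. Any claim that something is new, unique, unknown or untested is made for them only; others in the source may bear on it.

Measured so far, in a functional assay on BT-549 cells (Homo sapiens) for cytotoxicity, read by sulforhodamine B assay, with a stated time of 72 h; a lower number here means a stronger inhibitor, a higher number a weaker inhibitor:
compound 1 `CCS(=O)(=O)Nc1cc(-c2ccc3ncnc(Nc4ccc(OC(F)(F)F)cc4)c3c2)cnc1OC` gives 8240 nM
compound 2 `CCS(=O)(=O)Nc1cc(-c2ccc3ncnc(Nc4ccc(OC)c(Cl)c4)c3c2)cnc1OC` gives 2470 nM

Going by the values given here, compound 1 has the highest number of the two; the one step away from it, a 3.3-fold lower number from compound 1 to compound 2 (0.52 log units; beyond the scatter), is modest and beyond the scatter. Compound 3 `CCS(=O)(=O)Nc1cc(-c2ccc3ncnc(Nc4cccc(C(=O)OC)c4)c3c2)cnc1OC` is not yet measured. It differs from compound 1 in one place: 3-(methoxycarbonyl)phenyl in place of 4-(trifluoromethoxy)phenyl on a nitrogen on an aromatic ring. Among the compounds with values here, only that one step bears on this change, and it concerns a different group on the same nitrogen, so the direction is a guess. Compound 3 is expected to give 4500 nM, between 1500 nM and 13000 nM, a step of a 1.8-fold lower number from compound 1 to compound 3 (0.26 log units; within the scatter) that is estimated, not known.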

Compound 3, half-maximal inhibitory concentration: 1080 nM
Estimate against measurement, compound 3: 4.2-fold (0.62 log units) above; the measured number lies below the stated range.
By their numbers in this assay, from the lowest: compound 3; then compound 2; then compound 1.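

In this assay the group on this nitrogen can bring the number down further than compound 2 showed: 3-(methoxycarbonyl)phenyl gives a 7.6-fold lower number from compound 1 to compound 3 (0.88 log units; beyond the scatter) and also a 2.3-fold lower number from compound 2 to compound 3 (0.36 log units; beyond the scatter), both beyond the scatter. A ring carrying a methyl ester is therefore tolerated here, and it outdoes both 4-(trifluoromethoxy)phenyl and 3-chloro-4-methoxyphenyl. Nothing measured here gives a reason for this order.

Still open, going by these compounds, is whether the ester itself or its place on the ring sets the number. A carboxylic acid or an amide in place of the methyl ester would show how much depends on that ester.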